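The source may hold more compounds than are shown below. What is called first, only, known or untested is meant among the compounds shown, and "the series" means these compounds.

Compound 1 `Cn1ncc(Cl)c1-c1cc(C(=O)N[C@@H]2CN[C@H](CC(=O)O)C[C@H]2c2ccc(Cl)c(Cl)c2)oc1Cl`: 640 nM
Compound 2 `COCC[C@@H]1C[C@@H](c2ccc(Cl)c(Cl)c2)[C@H](NC(=O)c2cc(-c3c(Cl)cnn3C)c(Cl)o2)CN1`: 250 nM
Compound 3 `Cn1ncc(Cl)c1-c1cc(C(=O)N[C@@H]2CN[C@H](CC(=O)NCC(O)CO)C[C@H]2c2ccc(Cl)c(Cl)c2)oc1Cl`: 660 nM

In a functional assay on LNCaP cells (Homo sapiens) for antiproliferative activity (a higher number here means a weaker inhibitor, a lower number a stronger inhibitor), compound 3 gives the highest number of the three; compound 1 stands within the scatter of it (a 1.0-fold higher number from compound 1 to compound 3 (0.01 log units; within the scatter)), while compound 2 sits clearly lower (a 2.6-fold higher number from compound 2 to compound 3 (0.42 log units; beyond the scatter)). Compound 4 `Cn1ncc(Cl)c1-c1cc(C(=O)N[C@@H]2CN[C@H](CC(O)CO)C[C@H]2c2ccc(Cl)c(Cl)c2)oc1Cl` differs from compound 3 in one place: 1,2-dihydroxyethyl in place of (2,3-dihydroxypropyl)carbamoyl on a saturated chain carbon bound to a saturated ring carbon. Among the measured compounds shown here, two measured steps bear on this. The step of a 2.6-fold lower number from compound 1 to compound 2 (0.41 log units; beyond the scatter), where a chain without a carbonyl replaced carboxy, lowered the number modestly, and the step of a 1.0-fold higher number from compound 1 to compound 3 (0.01 log units; within the scatter) showed that changing the group on the carbonyl carbon did nothing beyond the scatter. A modest step toward a lower number is therefore expected, as a 1.7-fold lower number from compound 3 to compound 4 (0.22 log units; within the scatter). For compound 4 the estimated value is 400 nM, with a range from 180 nM to 900 nM.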

Compound 4, half-maximal inhibitory concentration: 70 nM
Compound 4: the middle estimate sits 5.7-fold (0.76 log units) above what was measured, outside the stated range (below it).
By their numbers in this assay, from the lowest: compound 4; then compound 2; then compounds 1 and 3 (each within the scatter of the next).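

In this assay, the step to 1,2-dihydroxyethyl at this place, a 9.4-fold lower number from compound 3 to compound 4 (0.97 log units; beyond the scatter), is far larger than anything the carbonyl-bearing groups had shown, and the same group also outdoes carboxy, a 9.1-fold lower number from compound 1 to compound 4 (0.96 log units; beyond the scatter). It goes beyond methoxymethyl as well, a 3.6-fold lower number from compound 2 to compound 4 (0.55 log units; beyond the scatter), so among these carbonyl-free chains the outcome depends on which group the chain carries, and compound 4 is the strongest of the four. No supporting data explain this gain. Still open, from the compounds shown here alone, is whether both hydroxy groups are needed, since a single hydroxy chain does not appear here. Nor do the compounds show how an amine or a longer diol chain would behave at this place.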